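The source may report more compounds than this note shows. Statements on the series, on what has been measured and on what is new or still open speak of the compounds shown alone.

Working notes on the series. Among the measured compounds shown here, compound 1 `COc1cc(CC2C(C#N)=C(N)N(c3ccc(S(N)(=O)=O)cc3)C3=C2C(=O)CCC3)ccc1O` and compound 2 `COc1ccc(C2C(C#N)=C(N)N(c3ccc(S(N)(=O)=O)cc3)C3=C2C(=O)CCC3)c2ccccc12` are the two measured members, and both carry the same core; they differ only in the group on one saturated ring carbon. In a functional assay on Ehrlich cells (Mus musculus) for antiproliferative activity, read by trypan blue exclusion, with a stated time of 2 h, tested at 10 ug/mL (on this read-out higher numbers stand for a stronger effect at the one concentration tested and lower numbers for a weaker effect), compound 1 gives 0%. In this assay compound 2 gives 10%. For the measured compounds named here, the one single-site step recorded is a number 10 percentage points higher from compound 1 to compound 2 (within the scatter). Compound 2 thus stands with the numerically larger of the two numbers, but compound 1 sits within the scatter of it, so the two are indistinguishable here and neither shows an effect at the single concentration.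

Compound 3 `N#CC1=C(N)N(c2ccc(S(N)(=O)=O)cc2)C2=C(C(=O)CCC2)C1c1ccco1` is the next member to be measured. Its change from compound 2 is furan-2-yl in place of 4-methoxynaphthalen-1-yl on a saturated ring carbon. Going by the values given here, the only step that bears on this change is the exchange at the same saturated ring carbon, a number 10 percentage points higher from compound 1 to compound 2 (within the scatter), which stayed within the scatter. Two different groups at that position have both given numbers near the floor of the read-out, so no step beyond the scatter is expected in this assay for a third group there. The step from compound 2 is therefore expected to be a number 5 percentage points lower from compound 2 to compound 3 (within the scatter). Compound 3 is estimated to give 5%, with a range from 0% to 25%.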

Compound 3, a percentage reported as activity, at one concentration (the size of the read-out at that concentration, not a potency): 0%
Compound 3: the middle estimate sits 5 percentage points above what was measured; the measured number falls inside the stated range.
By their numbers in this assay, from the lowest: compounds 1, 3 and 2 (each within the scatter of the next).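

In this assay the exchange of 4-methoxynaphthalen-1-yl, with 12 heavy atoms and 2 six-membered aromatic rings of carbon only, for furan-2-yl, with 5 heavy atoms and one five-membered aromatic ring with 1 hetero atom, gives a number 10 percentage points lower from compound 2 to compound 3 (within the scatter) on the same saturated ring carbon. Set against the 4-hydroxy-3-methoxybenzyl group, furan-2-yl gives no change at the digits printed from compound 1 to compound 3 (within the scatter) at that carbon, so three groups of quite different heavy-atom count and ring type now cannot be told apart on this read-out, and even the smallest of them leaves the number in the same band near the floor. No independent measurement bears on why the position is flat in this way.

Whether any group on this carbon can move the number clear of the scatter stays open, since the compounds shown offer no reading for an amine, a carboxylic acid or a longer alkyl chain there. As far as these compounds go, the 4-sulfamoylphenyl and cyano groups are the same in all three compounds, so what a change at either of those sites would do also remains open.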